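Ethynyloxy in place of hydroxybutynyl on the uracil nucleoside

This account rests on a few compounds, and the source may have more. Where it says the series, first, only, none or still open, it means among the compounds named here.

The set of compounds measured in an ADME assay on L1210/0 cells (Mus musculus) for cytotoxicity, with a stated time of 48 h (a higher number here means a weaker inhibitor, a lower number a stronger inhibitor), is small. Compound 1 `O=C1O/C(=C\Cn2cc(Cl)c(=O)[nH]c2=O)C(OCc2ccccc2)=C1OCc1ccccc1` has a different core and gives 12200 nM. Compound 2 `O=c1[nH]c(=O)n([C@H]2C[C@H](O)[C@@H](CO)O2)cc1C#CCCO` reaches only a limit of the assay, > 200000 nM, and no number is known for it. Compound 3 `Cc1ccc(S(=O)(=O)OCCC#Cc2cn([C@H]3C[C@H](O)[C@@H](CO)O3)c(=O)[nH]c2=O)cc1` likewise sits at a limit of the assay, > 200000 nM. For the measured compounds named here, the one step between measured compounds that differ in one place, a step that the two limits leave unreadable from compound 2 to compound 3, is therefore unreadable, since both ends are limits; its change is (4-methylphenyl)sulfonyl in place of hydrogen on an oxygen on a saturated carbon. The evidence on this step is only (the limit of > 200000 nM in this assay, at which 2 of the 3 values shown sit).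

The compound not yet measured is compound 4 `C#COc1cn([C@H]2C[C@H](O)[C@@H](CO)O2)c(=O)[nH]c1=O`. It differs from compound 2 as follows: ethynyloxy in place of 4-hydroxybut-1-yn-1-yl on an aromatic carbon. Going by the values given here, no measured step bears on the loss of the hydrogen-bond donor or on the shortening of the chain, because the only related step, a step that the two limits leave unreadable from compound 2 to compound 3, is unreadable. With compound 2 at a limit and no readable step in hand, compound 4 is expected to remain near that limit, so the step of a number no higher from compound 2 to compound 4 (the limit leaves the size open) is estimated as none beyond the scatter. Compound 4 is therefore estimated at 200000 nM, within 60000 nM to 700000 nM, and most likely reported as a limit again.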

Compound 4, half-maximal inhibitory concentration: > 200000 nM
Compound 4: no number, only a limit (the forecaster's own chance of this, stated with the estimate: 75%); the middle value lies on the limit itself.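

In this assay compound 4 gives > 200000 nM, which is a limit and not a number. Compound 2 also stands at a limit, so no new step can be read between compound 2 and compound 4. Whether compound 2, compound 3 and compound 4 differ at all stays open, because all three rest on the same limit: the limit of > 200000 nM in this assay, at which 3 of the 4 values shown sit.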